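Nitro for hydrogen on the phenyl ring: compound 4

A few compounds are considered here, and "the series" means these few. Any claim that something is new, unique, unknown or untested is made for them only; others in the source may bear on it.

Compound 1 `O=C(O)COC/C=C1\C[C@H]2C[C@@H](O)[C@H](/C=N/NC(=O)Nc3ccccc3)[C@H]2C1` gives 6000 nM in a functional assay on a cell-free system (plasma) for agonist activity at thromboxane A2 receptor (Homo sapiens) (a lower number here means a stronger inhibitor, a higher number a weaker inhibitor), the highest number of the three measured compounds. Compound 2 `O=C(O)COC/C=C1/C[C@H]2C[C@@H](O)[C@H](/C=N/NC(=O)Nc3ccccc3)[C@H]2C1` gives 1400 nM in this assay, and the step of a 4.3-fold lower number from compound 1 to compound 2 (0.63 log units; beyond the scatter) rests on (the fact that compounds 1 and 2 differ only in the configuration as drawn). Compound 3 `O=C(O)CCC/C=C1\C[C@H]2C[C@@H](O)[C@H](/C=N/NC(=O)Nc3ccccc3)[C@H]2C1` gives 1700 nM in this assay, the step being a 3.5-fold lower number from compound 1 to compound 3 (0.55 log units; beyond the scatter).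

Compound 4 `O=C(O)COC/C=C1\C[C@H]2C[C@@H](O)[C@H](/C=N/NC(=O)Nc3ccc([N+](=O)[O-])cc3)[C@H]2C1` is compound 1 with the change (nitro in place of hydrogen on an aromatic carbon). Both measured steps, from compound 1 to compound 2 and from compound 1 to compound 3, alter the acid-bearing chain on the other side of the shared core and leave the phenyl untouched; neither bears directly on a substituent on that ring. The two steps show that modest moves in either direction from compound 1 occur within this series, but they give no guide to the size or sign of the present change. No step beyond the scatter is therefore expected in this assay for compound 4, with wide uncertainty on either side. Compound 4 is estimated at 5000 nM in this assay, within 1500 nM to 16000 nM, meaning an expected step of a 1.2-fold lower number from compound 1 to compound 4 (0.08 log units; within the scatter).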

Compound 4, half-maximal inhibitory concentration: 190 nM
Beside the measured number, compound 4's estimate is 26-fold (1.42 log units) above it, outside the stated range (below it).
By their numbers in this assay, from the lowest: compound 4; then compounds 2 and 3 (each within the scatter of the next); then compound 1.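

The phenyl ring of compound 1 now proves to be a responsive part of the series: nitro in place of hydrogen on an aromatic carbon, para to a large group, gives a 32-fold lower number from compound 1 to compound 4 (1.50 log units; beyond the scatter) in this assay, a large step. The earlier steps shown here were both modest and both lay in the acid-bearing chain, so they said nothing about this ring, and this single change on it is larger than either of them. Nothing at hand bears on why nitro at this place has so large an effect.

The compounds shown leave open whether the step belongs to nitro itself or would also appear with another group at the same place, such as an amine, a methoxy group or a nitrile. They also leave open whether 4-nitrophenyl in place of phenyl would give a step of similar size on compound 2 or compound 3, where the acid-bearing chain differs from that of compound 1.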